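The source may hold more compounds than are shown below. What is called first, only, known or untested is meant among the compounds shown, and "the series" means these compounds.

Of the compounds shown here, three sharing one core have been measured in an assay on Cerebral cortex for displacement of a labelled ligand from adenosine receptor A1 (Bos taurus); a higher number here means a weaker inhibitor, a lower number a stronger inhibitor. Compound 1 `CNc1nc(-c2ccccc2)nc2c1nnn2Cc1ccccc1Cl` gives 191 nM in this assay, and compound 2 `CCCCCCNc1nc(-c2ccccc2)nc2c1nnn2Cc1ccccc1Cl` gives 31 nM. Compound 3 `c1ccc(Cn2nnc3c(NC4CC4)nc(-c4ccccc4)nc32)cc1` gives 11.3 nM, the lowest of the three numbers: its nearest neighbour is compound 2 and its furthest is compound 1, and both gaps are wider than the usual scatter of this kind of measurement.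

Compound 4 `Clc1ccccc1Cn1nnc2c(NC3CC3)nc(-c3ccccc3)nc21` is compound 3 with a single change: chloro in place of hydrogen on an aromatic carbon. Going by the values given here, the only step measured so far, a 6.2-fold lower number from compound 1 to compound 2 (0.79 log units; beyond the scatter), concerns a different place, the chain on the amine nitrogen, so nothing measured speaks directly to adding chloro to the benzyl ring. Compounds 1 and 2 already carry that chloro group, but no partner lacking it has been measured beside them, so their numbers show only where that pair stands. The expected step, a 1.3-fold lower number from compound 3 to compound 4 (0.10 log units; within the scatter), is therefore one that stays within the scatter. Compound 4 is estimated at 9 nM, with a range from 3 nM to 27 nM.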

Compound 4, inhibition constant: 11 nM
The estimate for compound 4 lay 1.2-fold (0.09 log units) below the measured number, within the range that was stated.
By their numbers in this assay, from the lowest: compounds 4 and 3 (each within the scatter of the next); then compound 2; then compound 1.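

In this assay the change from benzyl to 2-chlorobenzyl gives a 1.0-fold lower number from compound 3 to compound 4 (0.01 log units; within the scatter) and so makes no measurable difference at this place on the ring, at least while cyclopropyl sits on the amine nitrogen. With 2-chlorobenzyl held fixed, the groups on that nitrogen can now be compared directly: cyclopropyl in place of hexyl gives a 2.8-fold lower number from compound 2 to compound 4 (0.45 log units; beyond the scatter) and cyclopropyl in place of methyl gives a 17-fold lower number from compound 1 to compound 4 (1.24 log units; beyond the scatter) in this assay, so here the choice of nitrogen group moves the number while the chloro does not. Nothing available explains these numbers.

As far as these compounds go, compounds 1 and 2 have no partner lacking chloro, so whether chloro is equally without effect alongside methyl or hexyl stays open. From the compounds shown here alone, what bromo or methoxy would do on this ring also remains unknown.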